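A Benzimidazole Side Chain Tested on the Compound 2 Scaffold

This account rests on a few compounds, and the source may have more. Where it says the series, first, only, none or still open, it means among the compounds named here.

Compound 1, `CCO/C(O)=C1\C(COCCn2nncc2C(N)=O)=NC(C)=C(C(=O)OC)C1c1cccc(Cl)c1Cl`: 15.9 nM
Compound 2, `CCO/C(O)=C1\C(COCCn2nncc2C(N)=O)=NC(C)=C(C(=O)OC)C1c1ccccc1Cl`: 100 nM
Compound 3, `CCO/C(O)=C1\C(COCCn2cc(C(N)=O)nn2)=NC(C)=C(C(=O)OC)C1c1cccc(Cl)c1Cl`: 3.16 nM

In a functional assay (aorta) with Rattus norvegicus as the target (on this read-out higher numbers stand for weaker inhibition and lower numbers for stronger inhibition), compound 2 stands highest of the three numbers. The step of a 6.3-fold higher number from compound 1 to compound 2 (0.80 log units; beyond the scatter) separates it from its nearest neighbour, and compound 3 lies furthest from it. Compound 4, `CCO/C(O)=C1\C(COCCn2cnc3ccccc32)=NC(C)=C(C(=O)OC)C1c1ccccc1Cl`, is drawn from compound 2 by the change (1H-benzimidazol-1-yl in place of 5-carbamoyl-1H-1,2,3-triazol-1-yl on a saturated chain carbon, two bonds along the chain from an oxygen on a saturated carbon). Among the measured compounds shown here, no measured step covers this exchange: the step of a 5.0-fold lower number from compound 1 to compound 3 (0.70 log units; beyond the scatter) sits at the same place but swaps one carbamoyl-triazole for another, and the step from compound 1 to compound 2 concerns the chloro group. The expectation therefore rests on compound 2 alone, with wide uncertainty, and for compound 4 the expected step is a 1.7-fold lower number from compound 2 to compound 4 (0.22 log units; within the scatter). The estimate for compound 4 in this assay is 60 nM, within 10 nM to 400 nM.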

Compound 4, half-maximal inhibitory concentration: 20 nM
For compound 4 the middle estimate is 3.0-fold (0.48 log units) above the measured one; measured number inside the range.
By their numbers in this assay, from the lowest: compound 3; then compounds 1 and 4 (each within the scatter of the next); then compound 2.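

In this assay, the step of a 5.0-fold lower number from compound 2 to compound 4 (0.70 log units; beyond the scatter) shows that this position tolerates more than an exchange of one carbamoyl-triazole for another. Here 1H-benzimidazol-1-yl, which carries no carbamoyl group, replaces 5-carbamoyl-1H-1,2,3-triazol-1-yl with a gain in inhibition, so the carbamoyl group is not needed for activity in compound 4. Nothing shown here explains this gain. As far as these compounds go, whether 1H-benzimidazol-1-yl acts the same way on the core of compound 1, with its additional chloro group, remains open. So does how an amine or a carboxylic acid would fare on this chain.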